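The source may hold more compounds than are shown below. What is called first, only, known or untested is meant among the compounds shown, and "the series" means these compounds.

Of the compounds shown here, three built on one shared core have been measured in a functional assay on MCF7 cells (Homo sapiens) for cytotoxicity, read by MTT assay, with a stated time of 72 h; on this read-out lower numbers stand for stronger inhibition of growth and higher numbers for weaker inhibition of growth. Compound 1 `CCCCC[Se]c1nc([Se]CCCCC)c2cccnc2n1` gives 40800 nM in this assay. Compound 2 `CCCCC[Se]c1nc(NCc2ccc(SC)cc2)c2ccccc2n1` gives 34700 nM in this assay. Compound 3 `CCCCC[Se]c1nc([Se]CCCCC)c2ccccc2n1` gives 38400 nM in this assay. On these three numbers compound 3 stands second highest; its nearest neighbour is compound 1 and its furthest is compound 2, and both of those gaps lie within the scatter, so the three values cannot be told apart from one another.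

Compound 4 `CCCCC[Se]c1nc(NCc2ccccc2)c2ccccc2n1` has not yet been measured in this assay. It differs from compound 3 by a group of 8 heavy atoms (7 carbon, 1 nitrogen; one six-membered aromatic ring of carbon only) in place of a group of 6 heavy atoms (5 carbon, 1 selenium; no ring), on an aromatic carbon. Among the compounds with values here, no step between two measured compounds follows exactly this change, so its size can only be inferred. Compound 2, however, carries a closely related benzylamino group in place of one of the selenium-bearing chains on the same core, and its value sits with those of compound 1 and compound 3. The step of a 1.1-fold lower number from compound 3 to compound 4 (0.04 log units; within the scatter) is therefore expected to be none beyond the scatter, because compound 2 gives 34700 nM. Compound 4 is accordingly estimated at 35000 nM in this assay, with a range from 15000 nM to 80000 nM.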

Compound 4, concentration for 50% growth inhibition: 50 nM
Compound 4: the middle estimate sits 700-fold (2.85 log units) above what was measured, outside the stated range (below it).
By their numbers in this assay, from the lowest: compound 4; then compounds 2, 3 and 1 (each within the scatter of the next).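

In this assay, within the data shown here, benzylamino in place of the selenium-bearing group of 6 heavy atoms on this aromatic carbon brings a 770-fold lower number from compound 3 to compound 4 (2.89 log units; beyond the scatter), so a change at this position of the shared core can go with a very large difference, which the earlier compounds, all within the scatter of one another, did not show. The nitrogen-linked benzyl unit is not enough on its own, since hydrogen in place of methylsulfanyl on an aromatic carbon brings a 690-fold lower number from compound 2 to compound 4 (2.84 log units; beyond the scatter), and compound 2, which carries that methylsulfanyl group, stays with compound 1 and compound 3; the result therefore depends on the substitution of the benzyl ring as well as on the exchange at the core. Nothing among the data given accounts for either step.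

The compounds shown leave open whether a small group such as fluorine or methoxy on the benzyl ring would keep the low number of compound 4 or lose it as methylsulfanyl does. They also leave open whether a longer chain between the nitrogen and the ring, or a replacement of the remaining selenium-bearing group with an amine, would be tolerated.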